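Benzyl for pyridinylmethyl: where compound 3 may land

The source may report more compounds than this note shows. Statements on the series, on what has been measured and on what is new or still open speak of the compounds shown alone.

Of the compounds shown here, two sharing one core have been measured in a physicochemical assay for lipophilicity, at pH 7.4; on this read-out higher numbers stand for higher lipophilicity and lower numbers for lower lipophilicity. Compound 1, `CNC(=O)c1cc(C(=O)NC(C)C)cn(Cc2ccccc2)c1=O`, carries a benzyl group on the ring nitrogen and an isopropyl amide; in this assay compound 1 gives 3.6. Compound 2, `CNC(=O)c1cc(C(=O)NC2CCC2)cn(Cc2ccccn2)c1=O`, carries a (pyridin-2-yl)methyl group and a cyclobutyl amide; in this assay compound 2 gives 2.2, the lower of the two numbers, with compound 1 standing well above it, beyond the usual scatter. For the measured compounds named here, the two differ in two places at once, so no single step between them can be read off.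

Compound 3, `CNC(=O)c1cc(C(=O)NC2CCC2)cn(Cc2ccccc2)c1=O`, keeps the cyclobutyl amide of compound 2 and changes one thing: phenyl in place of pyridin-2-yl on a saturated chain carbon bound to an aromatic nitrogen. The group that leaves brings one hydrogen-bond acceptor; the group that enters brings none.

In this assay the step from compound 2 to compound 3 is expected to be upward and clearly beyond the scatter, about a number 1.70 log units higher from compound 2 to compound 3 (beyond the scatter), because compound 1, which already carries the benzyl group, gives 3.6. Compound 3 is therefore estimated at 3.9, expected between 3.3 and 4.5.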

Compound 3, distribution coefficient: 3.8
The estimate for compound 3 lay 0.10 log units above the measured number; low and high end bracket the measured number.
By their numbers in this assay, from the lowest: compound 2; then compounds 1 and 3 (each within the scatter of the next).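

With the amide held as cyclobutyl, the change at this position can now be read on its own: in this assay, phenyl in place of pyridin-2-yl on a saturated chain carbon bound to an aromatic nitrogen gives a number 1.60 log units higher from compound 2 to compound 3 (beyond the scatter), a large step for an exchange that keeps the ring size and the heavy-atom count and removes the one hydrogen-bond acceptor of the leaving group. For the compounds shown here, the amide can also be read alone for the first time, since cyclobutyl in place of isopropyl on an amide-type nitrogen gives a number 0.20 log units higher from compound 1 to compound 3 (within the scatter), so with the benzyl group in place this exchange does not separate the two compounds on this read-out. Nothing available explains why the ring exchange moves the number by so much.

The compounds shown leave open whether the ring exchange gives a step of similar size with the isopropyl amide, as it is seen here only with the cyclobutyl amide. Also open, going by these compounds, is how the number would respond to an amine or a carboxylic acid on the phenyl ring, or to a longer chain carrying that ring.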